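Fluoro for nitro: notes on the series

The source may hold more compounds than are shown below. What is called first, only, known or untested is meant among the compounds shown, and "the series" means these compounds.

Values from a functional assay on MCF7 cells (Homo sapiens) for cytotoxicity, read by MTT assay, with a stated time of 48 h (on this read-out higher numbers stand for weaker inhibition and lower numbers for stronger inhibition), are as follows.
- Compound 1 `CCn1c(/C=C2/C(=O)Nc3ccc(F)cc32)nc2ccccc21` gives > 50000 nM, which is a limit.
- Compound 2 `CC(C)n1c(/C=C2/C(=O)Nc3ccccc32)nc2ccccc21` gives 39500 nM.
- Compound 3 `Cn1c(/C=C2/C(=O)Nc3ccc([N+](=O)[O-])cc32)nc2ccccc21` gives "not determined" (no result reported).

Compound 3 has no single number on this read-out, so it cannot be placed against the others. Within the data shown here, the series so far shows (the limit of > 50000 nM in this assay, at which 1 of the 3 values shown sits). Still to be measured is compound 4 `Cn1c(/C=C2/C(=O)Nc3ccc(F)cc32)nc2ccccc21`. The structural change is fluoro in place of nitro on an aromatic carbon, meta to a fused ring and para to a fused ring. With no number for compound 3, neither a size nor a direction of step in this assay can be expected from it. The expectation therefore rests on the other two compounds. Compound 1 carries the same fluoro and stands at > 50000 nM, a limit. Compound 2 stands at 39500 nM. For compound 4 the expected value is 40000 nM, with an estimated range of 15000 nM to 70000 nM.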

Compound 4, half-maximal inhibitory concentration: 31600 nM
For compound 4 the middle estimate is 1.3-fold (0.10 log units) above the measured one, within the range that was stated.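

In this assay, among these compounds, compound 4 gives 31600 nM, the first exact number for fluoro on this aromatic carbon, meta to a fused ring and para to a fused ring. The step from nitro to fluoro cannot be read, since compound 3 has no reported result. With fluoro held in place, hydrogen in place of methyl on the saturated chain carbon bound to the aromatic nitrogen gives an at least 1.5-fold lower number from compound 1 to compound 4 (0.19 log units; that floor lies within the scatter), and this step rests on a limit for compound 1: the limit of > 50000 nM in this assay, at which 1 of the 4 values shown sits.

From the compounds shown here alone, how nitro and fluoro compare at this carbon remains open. Also open, going by these compounds, is how an amine or a carboxylic acid at this carbon, or a butyl chain on the aromatic nitrogen, would read in this assay.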